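The compounds below may be only part of what the source reports. "The series", "measured", "known", "first", "only" and "open" are said of these compounds alone.

Measured so far:
- compound 1 `CCCCCc1ccc(-c2cc3cn([C@H]4C[C@H](O)[C@@H](COC(=O)[C@@H](NC(=O)[C@@H]5CCCN5C(=O)[C@@H](N)C(C)C)C(C)C)O4)c(=O)nc3o2)cc1`: 1200 ug/mL
- compound 2 `CCCCCc1ccc(-c2cc3cn([C@H]4C[C@H](OC(=O)[C@@H](NC(=O)[C@@H]5CCCN5C(=O)[C@@H](N)C(C)C)C(C)C)[C@@H](COC(=O)[C@@H](NC(=O)[C@@H]5CCCN5C(=O)[C@@H](N)C(C)C)C(C)C)O4)c(=O)nc3o2)cc1`: 77000 ug/mL

Both were tested in a physicochemical assay for solubility, with a stated time of 24 h; on this read-out higher numbers stand for higher solubility and lower numbers for lower solubility. Compound 1 gives the lower of the two numbers; compound 2, which carries a second ester arm on its sugar ring, gives a number that is higher by a gap beyond the usual scatter. Compound 3 `CCCCCc1ccc(-c2cc3cn([C@H]4C[C@H](O)[C@@H](COC(=O)[C@@H](NC(=O)[C@@H]5CCCN5C(=O)[C@@H](N)CCCCN)C(C)C)O4)c(=O)nc3o2)cc1` has not yet been measured in this assay. It differs from compound 1 in one place: 4-aminobutyl in place of isopropyl on a saturated chain carbon bound to an amine nitrogen and a carbonyl carbon. Among the measured compounds shown here, no measured pair shows this same change, so its effect on this assay can only be expected, not read off. For the measured compounds named here, with no directly comparable step to rest on, the step from compound 1 to compound 3 is expected to be modest and upward, on the order of a 3.3-fold higher number from compound 1 to compound 3 (0.52 log units; beyond the scatter), with a fair chance that it stays within the scatter. Compound 3 is thus estimated at 4000 ug/mL, in a range from 1200 ug/mL to 15000 ug/mL.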

Compound 3, solubility: 55000 ug/mL
Estimate against measurement, compound 3: 14-fold (1.14 log units) below; the whole stated range lies below it.
By their numbers in this assay, from the lowest: compound 1; then compounds 3 and 2 (each within the scatter of the next).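

Replacing isopropyl with 4-aminobutyl on a saturated chain carbon bound to an amine nitrogen and a carbonyl carbon gives, in this assay, a 46-fold higher number from compound 1 to compound 3 (1.66 log units; beyond the scatter) as a large step. Among the compounds shown here, this is the first look at this position, and it shows that the number can move strongly with a change to this one group while the rest of the molecule stays the same. No measurement shown here explains the rise.

The swap changes two things at once, the chain and its end amine, so the compounds shown cannot say which of them matters. A plain butyl chain without the amine, a shorter 2-aminoethyl chain or a chain ending in a carboxylic acid would each test a different part of this question.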